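This account rests on a few compounds, and the source may have more. Where it says the series, first, only, none or still open, it means among the compounds named here.

In an ADME assay on MT4 cells (Homo sapiens) for cytotoxicity (on this read-out higher numbers stand for lower toxicity in this test and lower numbers for higher toxicity in this test), compound 1 (`CCNC(=S)Nc1cccc(C(F)(F)F)c1`) gives > 100000 nM, which is a limit of the assay and not a number. Among the measured compounds shown here, compound 2 (`FC(F)(F)c1cccc(NC(=S)NCc2ccco2)c1`) gives 43000 nM, the only true number so far. Compound 3 (`FC(F)(F)c1cccc(NC(=S)Nc2ccccc2Br)c1`) has 2-bromophenyl in place of (furan-2-yl)methyl on an amide-type nitrogen. For the measured compounds named here, the one measured step that bears on this change, an at least 2.3-fold lower number from compound 1 to compound 2 (0.36 log units; beyond the scatter), also replaced a group on that side and led to a lower number. On that evidence alone, a further modest move toward a lower number is expected in this assay. The expected size is a 2.9-fold lower number from compound 2 to compound 3 (0.46 log units; beyond the scatter). For compound 3, the estimate is 15000 nM, with a range from 4000 nM to 60000 nM.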

Compound 3, half-maximal cytotoxic concentration: 36000 nM
Beside the measured number, compound 3's estimate is 2.4-fold (0.38 log units) below it; the measured number falls inside the stated range.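

In this assay, 2-bromophenyl in place of (furan-2-yl)methyl on the amide-type nitrogen gives a 1.2-fold lower number from compound 2 to compound 3 (0.08 log units; within the scatter), so the two groups cannot be told apart at this position. Set against ethyl, 2-bromophenyl gives an at least 2.7-fold lower number from compound 1 to compound 3 (0.44 log units; beyond the scatter), and thus both ring-bearing groups part from ethyl in the same direction. Compound 1 stands at a limit and not a number, so the size of that step stays open: the limit of > 100000 nM in this assay, at which 1 of the 3 values shown sits.

From the compounds shown here alone, whether a longer chain such as butyl on that nitrogen would behave like ethyl or like the ring-bearing groups stays open. So does whether plain phenyl would match 2-bromophenyl.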